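The source may hold more compounds than are shown below. What is called first, only, known or untested is meant among the compounds shown, and "the series" means these compounds.

Compound 1 `O=C(Nc1ccc(S(=O)(=O)NC2CCCC2)cc1)C1C(C(=O)O)[C@H]2CC[C@@H]1O2` in a functional assay on HeLa cells (Homo sapiens) for cytotoxicity, read by MTT assay, with a stated time of 48 h (a lower number here means a stronger inhibitor, a higher number a weaker inhibitor), gives 17600 nM. Compound 2 `O=C(Nc1ccc(S(=O)(=O)NC2CC2)cc1)C1C(C(=O)O)[C@H]2CC[C@@H]1O2` gives 20900 nM. Compound 3 `CCOC(=O)Cc1csc(NC(=O)C2C(C(=O)O)[C@H]3CC[C@@H]2O3)n1` gives only a limit, > 100000 nM, which is the limit of > 100000 nM in this assay, at which 1 of the 3 values shown sits.

Among the two numbers, compound 2 sits beside compound 1: the step of a 1.2-fold higher number from compound 1 to compound 2 (0.07 log units; within the scatter) lies within the scatter, so the two are not separated. The third compound contributes a limit, not a number.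

Compound 4 `O=C(Nc1ccc(S(=O)(=O)NC2CCCCC2)cc1)C1C(C(=O)O)[C@H]2CC[C@@H]1O2` is the cyclohexyl analogue. Measured against compound 2, the change is cyclohexyl in place of cyclopropyl on a sulfonamide nitrogen. For the measured compounds named here, the one step that bears on this is the one from compound 1 to compound 2, cyclopropyl in place of cyclopentyl on the same sulfonamide nitrogen, and it was a 1.2-fold higher number from compound 1 to compound 2 (0.07 log units; within the scatter), which is within the scatter. Going from cyclopropyl to cyclohexyl extends that same series by one ring size in the other direction, so the expectation for compound 4 in this assay is a step of a 1.4-fold lower number from compound 2 to compound 4 (0.14 log units; within the scatter), which is not expected to go beyond the scatter. Compound 4 is therefore estimated at 15000 nM, with a range from 7000 nM to 35000 nM.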

Compound 4, half-maximal inhibitory concentration: 18700 nM
The estimate for compound 4 lay 1.2-fold (0.10 log units) below the measured number; the measured number falls inside the stated range.
By their numbers in this assay, from the lowest: compounds 1, 4 and 2 (each within the scatter of the next). At a limit, above all of these: compound 3.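

For the compounds shown here, with cyclohexyl on the sulfonamide nitrogen, three ring sizes can now be read at this place in this assay, and no step separates them: there is a 1.1-fold lower number from compound 2 to compound 4 (0.05 log units; within the scatter), and there is a 1.1-fold higher number from compound 1 to compound 4 (0.03 log units; within the scatter). Going by these compounds alone, the earlier compounds offered only a single step, between cyclopentyl and cyclopropyl, whereas these three compounds show that moving from a three-membered ring of 3 carbon atoms to a six-membered ring of 6 carbon atoms, with cyclopentyl as a further ring size, leaves the numbers within the scatter of one another. Nothing measured here accounts for this flat response at the sulfonamide nitrogen.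

The compounds shown carry only all-carbon rings at this place, so it remains open whether an open chain such as n-butyl, or a group bearing an amine or a carboxylic acid, would separate from them in this assay. Also open, from the compounds shown here alone, is what an ethyl ester in place of the carboxylic acid on the shared core would do to the number, with the cyclohexyl group and the rest of compound 4 kept unchanged.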